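A few compounds are considered here, and "the series" means these few. Any claim that something is new, unique, unknown or untested is made for them only; others in the source may bear on it.

Compound 2 `N=C(NCCCc1c[nH]cn1)NCCC(c1ccc(Cl)c(Cl)c1)c1ccccn1` gives 8.19 in a functional assay on cardiac atrium for agonist activity at histamine H2 receptor (Cavia porcellus) (a lower number here means a less potent compound, a higher number a more potent compound, by a factor of ten per unit of this negative logarithm), the higher of the two values recorded so far. Among the compounds with values here, compound 1 `N=C(NCCCc1c[nH]cn1)NCCC(c1ccccn1)c1ccccc1F` gives 7.46 in this assay, and the only measured step, a number 0.73 log units higher from compound 1 to compound 2 (beyond the scatter), lies at the other aryl group on the shared core. Compound 3 `N=C(NCCCc1c[nH]cn1)NCCC(c1ccccc1)c1ccc(Cl)c(Cl)c1` differs from compound 2 by phenyl in place of pyridin-2-yl on a saturated chain carbon bound to an aromatic carbon and a saturated chain carbon. Within the data shown here, no measured step touches this position, so nothing in the present numbers speaks directly to an exchange of pyridin-2-yl for phenyl; the only information is that the rest of the molecule is held unchanged and that the one recorded step concerns a different ring. In the absence of a bearing step, compound 3 is expected to stay close to compound 2 in this assay, with a number 0.19 log units lower from compound 2 to compound 3 (within the scatter) as the estimated step. The estimate for compound 3 is therefore 8, within the range 7.4 to 8.6.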

Compound 3, negative logarithm of the half-maximal effective concentration: 7.46
Beside the measured number, compound 3's estimate is 0.54 log units above it, within the range that was stated.
By their numbers in this assay, from the lowest: compounds 1 and 3 (each within the scatter of the next); then compound 2.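

With the 3,4-dichlorophenyl group held fixed, the position on a saturated chain carbon bound to an aromatic carbon and a saturated chain carbon proves sensitive in this assay with a number 0.73 log units lower from compound 2 to compound 3 (beyond the scatter) as phenyl replaces pyridin-2-yl. The heavy-atom count stays the same, and the exchange of one ring nitrogen for carbon removes the hydrogen-bond acceptor counted for the leaving group, yet the step lies beyond the scatter and matches in size, though not in direction, the change at the other aryl group, where the series shows a number 0.73 log units higher from compound 1 to compound 2 (beyond the scatter) on the shared core. No measured information on the compounds explains the drop at this position.

As far as these compounds go, whether pyridin-2-yl holds the same advantage over phenyl alongside the 2-fluorophenyl group remains open. So does the response at this position to a cyclohexyl group or a plain methyl group in place of the ring.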